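The source may report more compounds than this note shows. Statements on the series, on what has been measured and on what is new or still open speak of the compounds shown alone.

Measured so far in an ADME assay on HEK293 cells (Homo sapiens) for cytotoxicity, read by luminescence, with a stated time of 72 h; a higher number here means that more compound is needed for the effect, a lower number that less compound is needed:
Compound 1 `CCOC(=O)c1c(-c2cccc(-c3ccccc3)c2)[nH]c2cc(Cl)ccc2c1=O`: > 22000 nM
Compound 2 `CCOC(=O)c1c(-c2cccc(-c3ccccc3)c2)[nH]c2cc(OC)c(OC)cc2c1=O`: > 22000 nM
Compound 3 `CCOC(=O)c1c(-c2cccc(OC)c2)[nH]c2cc(OC)c(OC)cc2c1=O`: > 22000 nM

Compound 2 gives > 22000 nM, which is a limit and not a number. It has no exact value to start from, and the other two compounds offer none either: the limit of > 22000 nM in this assay, at which 3 of the 3 values shown sit.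

Compound 4 `CCOC(=O)c1c(-c2cccc(-c3ccccc3)c2)[nH]c2cc(Cl)c(OC)cc2c1=O` keeps the whole of compound 2 except for one group on the core: chloro in place of methoxy on an aromatic carbon. The methoxy group that remains is ortho to the new chloro.

Among the measured compounds shown here, the one measured step between these compounds is a step that the two limits leave unreadable from compound 2 to compound 3. It changes a different group, and with a limit at both ends it has no readable size, so it gives no measure for the change in compound 4.

No step beyond the usual scatter is expected in this assay, in either direction, since compound 1 with its chloro group gives > 22000 nM, also a limit. A limit is the most likely report for compound 4 as well.

The expected change is a step that the limit leaves unreadable from compound 2 to compound 4.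

If a number is obtained, compound 4 is estimated at 25000 nM, within an expected range of 12000 nM to 50000 nM.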

Compound 4, half-maximal effective concentration: > 22000 nM
Compound 4: only a limit was reported (the forecaster's own chance of this, stated with the estimate: 85%); the middle value lies beyond the limit too.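

Compound 4 gives > 22000 nM in this assay, which is a limit and not a number. Its steps from compound 1 and compound 2 therefore cannot be read: the limit of > 22000 nM in this assay, at which 4 of the 4 values shown sit.

The compounds shown leave open what exact value any of them would give in this assay, and so whether chloro in place of methoxy changes that value at all.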